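A few compounds are considered here, and "the series" means these few. Any claim that something is new, unique, unknown or untested is made for them only; others in the source may bear on it.

Measured compounds:
compound 1, `CCCCC(N)c1cc(C(F)(F)F)ccc1N1CCN(C(=O)CCc2ccc(Cl)cc2Cl)CC1`, 190 nM
compound 2, `COc1cccc(CCC(=O)N2CCN(c3ccc(C(F)(F)F)cc3[C@@H](N)CC(C)C)CC2)c1`, 4000 nM
compound 3, `Cc1[nH]c2ccccc2c1CCC(=O)N1CCN(c2ccc(C(F)(F)F)cc2[C@@H](N)CC(C)C)CC1`, 1600 nM

In an assay on HEK293 cells for displacement of a labelled ligand from Melanocortin receptor 4 (Homo sapiens) (a higher number here means a weaker inhibitor, a lower number a stronger inhibitor), compound 1 gives the lowest of the three numbers: compound 3 sits a 2.5-fold lower number from compound 2 to compound 3 (0.40 log units; beyond the scatter), and compound 2 sits furthest. Going by the values given here, the one measured step, the change a 2.5-fold lower number from compound 2 to compound 3 (0.40 log units; beyond the scatter), alters the group on the chain carbon two bonds from the carbonyl; it says nothing about the aminoalkyl side of the shared core.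

Compound 4, `CCC(C)[C@H](NC[C@H]1CCCN1)c1cc(C(F)(F)F)ccc1N1CCN(C(=O)CCc2ccc(Cl)cc2Cl)CC1`, is not yet measured. It differs from compound 1 by 2-methyl-1-(((pyrrolidin-2-yl)methyl)amino)butyl in place of 1-aminopentyl on an aromatic carbon. Among the compounds with values here, no measured step touches this part of the molecule, so the direction of the change is open. The estimate for compound 4 is 150 nM, within 25 nM to 900 nM, a step of a 1.3-fold lower number from compound 1 to compound 4 (0.10 log units; within the scatter) that is expected to stay near the scatter.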

Compound 4, inhibition constant: 110 nM
Estimate against measurement, compound 4: 1.4-fold (0.13 log units) above; the range from low to high includes it.
By their numbers in this assay, from the lowest: compounds 4 and 1 (each within the scatter of the next); then compound 3; then compound 2.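

In this assay, putting 2-methyl-1-(((pyrrolidin-2-yl)methyl)amino)butyl in place of 1-aminopentyl gives a 1.7-fold lower number from compound 1 to compound 4 (0.24 log units; within the scatter). This aromatic carbon therefore accepts a much bigger group, with a five-membered non-aromatic ring and a second nitrogen, without a clear shift in the number. Nothing measured here explains this result.

Going by these compounds, the branched chain and the added ring arrive together in one step, so their separate contributions stay unknown. Also open, on these data alone, is how a six-membered piperidine ring or a simple dimethylamino group would behave at this position.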